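A few compounds are considered here, and "the series" means these few. Any claim that something is new, unique, unknown or untested is made for them only; others in the source may bear on it.

Measured compounds:
- compound 1 `CCCc1cnc2c(C#N)c(N3CCC(c4ccccc4)CC3)ccn12`: 155 nM
- compound 2 `N#Cc1c(N2CCC(c3ccccc3)CC2)ccn2c(CC(F)(F)F)cnc12`: 125 nM
- compound 3 `N#Cc1c(N2CCC(c3ccccc3)CC2)ccn2c(CC(F)(F)F)nnc12`: 56 nM

In a functional assay on CHO cells for positive allosteric modulation of metabotropic glutamate receptor 2 (Homo sapiens), read by GTPgammaS binding, with a stated time of 30 min (on this read-out higher numbers stand for an effect only at larger amounts of compound and lower numbers for an effect already at smaller amounts), compound 3 stands at the lowest of the three numbers, beyond the scatter from both compound 2 and compound 1. Compound 4 `COCc1nnc2c(C#N)c(N3CCC(c4ccccc4)CC3)ccn12` differs from it by methoxy in place of trifluoromethyl on a saturated chain carbon bound to an aromatic carbon. Going by the values given here, the only measured step at this place, a 1.2-fold lower number from compound 1 to compound 2 (0.09 log units; within the scatter), stayed within the scatter, so that site has so far tolerated exchange with little movement. Compound 4 is therefore expected to land near compound 3, with an estimated step of a 1.6-fold higher number from compound 3 to compound 4 (0.21 log units; within the scatter) in this assay, most likely a modestly higher number and possibly none beyond the scatter. The estimate for compound 4 is 90 nM, with a range from 35 nM to 250 nM.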

Compound 4, half-maximal effective concentration: 468 nM
Beside the measured number, compound 4's estimate is 5.2-fold (0.72 log units) below it; the measured number lies above the stated range.
By their numbers in this assay, from the lowest: compound 3; then compounds 2 and 1 (each within the scatter of the next); then compound 4.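

In this assay, methoxy in place of trifluoromethyl on a saturated chain carbon bound to an aromatic carbon gave an 8.4-fold higher number from compound 3 to compound 4 (0.92 log units; beyond the scatter), so this place is far less forgiving than the earlier exchange, a 1.2-fold lower number from compound 1 to compound 2 (0.09 log units; within the scatter), suggested. What enters at this place can therefore move the number well beyond the scatter, at least on the core of compound 3. Nothing measured here offers a reason for the step.

Going by these compounds, whether an amine or a hydroxyl at this place would keep the number near that of compound 3 stays open. So does whether methoxy would cost as much on the core of compound 2.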